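Chain-extended isothiocyanate analogues on a shared core

The compounds below may be only part of what the source reports. "The series", "measured", "known", "first", "only" and "open" are said of these compounds alone.

Compound 1 `CN(C)C(=O)c1cc2cnc(Nc3ccc(C(=O)NCCCCCCN=C=S)cc3F)nc2n1C1CCCC1` and compound 3 `CN(C)C(=O)c1cc2cnc(Nc3ccc(NC(=O)CCCCN=C=S)cc3)nc2n1C1CCCC1` carry an isothiocyanate on a saturated chain hung from the shared core; the difference between the two cores is not broken down here. In a functional assay on NCI-H1299 cells (Homo sapiens) for inhibition, read by CCK-8 assay, with a stated time of 72 h, tested at 10 uM (on this read-out higher numbers stand for a stronger effect at the one concentration tested and lower numbers for a weaker effect), compound 1 gives 77.6% and compound 3 gives 82.5%; these two lie within the scatter of each other. Compound 2 `CN(C)C(=O)c1cc2cnc(Nc3ccc(C(=O)NCCCCCCCN=C=S)cc3F)nc2n1C1CCCC1` differs from compound 1 by one change, (a group of 4 heavy atoms (2 carbon, 1 nitrogen, 1 sulfur; no ring) in place of a group of 3 heavy atoms (1 carbon, 1 nitrogen, 1 sulfur; no ring), on a saturated chain carbon, six bonds along the chain from an amide-type nitrogen), and in this assay compound 2 gives 35.8%, so that a number 41.8 percentage points lower from compound 1 to compound 2 (beyond the scatter).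

Compound 4 `CN(C)C(=O)c1cc2cnc(Nc3ccc(NC(=O)CCCCCN=C=S)cc3)nc2n1C1CCCC1` is not yet measured. It differs from compound 3 by a group of 4 heavy atoms (2 carbon, 1 nitrogen, 1 sulfur; no ring) in place of a group of 3 heavy atoms (1 carbon, 1 nitrogen, 1 sulfur; no ring), on a saturated chain carbon, four bonds along the chain from a carbonyl carbon. The group that leaves and the group that enters are the same kind of change as from compound 1 to compound 2, but the place is not the same word for word: in the earlier pair it is six bonds along the chain from an amide-type nitrogen, here four bonds along the chain from a carbonyl carbon. For the measured compounds named here, the only comparable step is the one from compound 1 to compound 2, a number 41.8 percentage points lower from compound 1 to compound 2 (beyond the scatter), and it rests on a single pair, so the step for compound 4 is expected at a number 30.5 percentage points lower from compound 3 to compound 4 (beyond the scatter), somewhat smaller given the different place. Compound 4 in this assay is therefore estimated at 52%, with a range from 30% to 74%.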

Compound 4, a percentage reported as inhibition, at one concentration (the size of the read-out at that concentration, not a potency): 85%
Estimate against measurement, compound 4: 33 percentage points below, and the stated range ends below it.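

In this assay the same change, the group of 4 heavy atoms in place of the group of 3 heavy atoms, gives a number 2.5 percentage points higher from compound 3 to compound 4 (within the scatter). The change therefore does not carry over as a fixed step from one core to the other in this series: the same change on two cores in this assay, a number 41.8 percentage points lower (beyond the scatter) from compound 1 to compound 2 and a number 2.5 percentage points higher (within the scatter) from compound 3 to compound 4, 44.3 percentage points apart, beyond the scatter of two such steps. This comparison rests on a single pair for each core, and the place also differs, six bonds along the chain from an amide-type nitrogen in one pair and four bonds along the chain from a carbonyl carbon in the other, so it does not show whether the core, the place or the chain length sets the gap.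

Still open, as far as these compounds go, is whether a longer chain on the core of compound 3 would bring a fall like the one seen on the core of compound 1. Also open, from the compounds shown here alone, is how either core would read with an amine or a carboxylic acid in place of the isothiocyanate.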